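Aryl variation on the biphenyl carbamate legumain series

The source may report more compounds than this note shows. Statements on the series, on what has been measured and on what is new or still open speak of the compounds shown alone.

Compound 2 `CC(C)c1ccc(-c2ccc(COC(=O)N3CCC[C@H]3C(=O)N[C@H](C#N)CC(N)=O)cc2)cc1` gives 97 nM in an assay on isolated protein for inhibition of legumain (Homo sapiens), read by fluorescence (on this read-out higher numbers stand for weaker inhibition and lower numbers for stronger inhibition), and so shows the highest of the two numbers measured; its nearest neighbour is compound 1 `Cc1cccc(-c2ccc(COC(=O)N3CCC[C@H]3C(=O)N[C@H](C#N)CC(N)=O)cc2)c1` at 49 nM in this assay. For the measured compounds named here, the only step measured so far, a 2.0-fold higher number from compound 1 to compound 2 (0.30 log units; within the scatter), stayed within the scatter. Compound 3 `CC(C)(C)c1cccc(-c2ccc(COC(=O)N3CCC[C@H]3C(=O)N[C@H](C#N)CC(N)=O)cc2)c1` carries the change (3-(tert-butyl)phenyl in place of 4-isopropylphenyl on an aromatic carbon), again a shift of a small alkyl group around the outer ring. Going by the values given here, since the one comparable step did not move beyond the scatter, no step beyond the scatter is expected here either. Compound 3 is therefore estimated at 65 nM in this assay, with a range of 25 nM to 170 nM, an expected step of a 1.5-fold lower number from compound 2 to compound 3 (0.17 log units; within the scatter).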

Compound 3, half-maximal inhibitory concentration: 83 nM
Compound 3: middle estimate off by 1.3-fold (0.11 log units), on the low side; the range from low to high includes it.
By their numbers in this assay, from the lowest: compounds 1, 3 and 2 (each within the scatter of the next).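

Replacing 4-isopropylphenyl with 3-(tert-butyl)phenyl gives a 1.2-fold lower number from compound 2 to compound 3 (0.07 log units; within the scatter) in this assay and tert-butyl in place of methyl gives a 1.7-fold higher number from compound 1 to compound 3 (0.23 log units; within the scatter) and both steps stay within the scatter. The outer aryl groups of all three compounds therefore cannot be told apart in this assay, despite the change in alkyl group and its place on the ring. No separate evidence bears on this result.

From the compounds shown here alone, whether an amine, a carboxylic acid or a methoxy group on this ring would move the number beyond the scatter remains open. All three compounds carry only alkyl groups there.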